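Para-substituent swap on a shared thiazolidinone core

The source may hold more compounds than are shown below. What is called first, only, known or untested is meant among the compounds shown, and "the series" means these compounds.

Measured compounds:
Compound 1 `O=C1CSC(c2ccc(O)cc2)N1CCN1CCCCC1`: 10%
Compound 2 `Cc1ccc(C2SCC(=O)N2CCN2CCCCC2)cc1`: 12%

In an ADME assay on Vero cells (Chlorocebus sabaeus) for cytotoxicity, read by neutral red uptake, tested at 3150 ug/mL (on this read-out lower numbers stand for a stronger effect and higher numbers for a weaker effect at the one concentration tested), compound 1 gives 10% and compound 2 gives 12%; the two numbers lie within the scatter of each other, as a number 2 percentage points higher from compound 1 to compound 2 (within the scatter) shows. Compound 3 `O=C1CSC(c2ccc(F)cc2)N1CCN1CCCCC1` has not yet been measured. The change is fluoro in place of methyl on an aromatic carbon. For the measured compounds named here, the one step that bears on it, a number 2 percentage points higher from compound 1 to compound 2 (within the scatter), also exchanged the group para to the large group and stayed within the scatter, so no step beyond the scatter is expected here either: the expected step is no change at the digits printed from compound 2 to compound 3 (within the scatter). Compound 3 is estimated at 12%, in the range 4% to 22%.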

Compound 3, a percentage reported as activity, at one concentration (the size of the read-out at that concentration, not a potency): 11%
Beside the measured number, compound 3's estimate is 1 percentage points above it; measured number inside the range.
By their numbers in this assay, from the lowest: compounds 1, 3 and 2 (each within the scatter of the next).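

In this assay, fluoro is a third group on this aromatic carbon, para to a large group, that gives no step beyond the scatter: the change shows a number 1 percentage points lower from compound 2 to compound 3 (within the scatter) and a number 1 percentage points higher from compound 1 to compound 3 (within the scatter) on the shared core. Hydroxy, methyl and fluoro therefore cannot be told apart here at the one concentration tested. Nothing available offers an explanation for this. Still open, going by these compounds, is whether a larger or charged group at this place, such as trifluoromethyl, an amine or a carboxylic acid, would also leave the read-out within the scatter.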